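Chloro substitution on the thioether ring of compound 1

A few compounds are considered here, and "the series" means these few. Any claim that something is new, unique, unknown or untested is made for them only; others in the source may bear on it.

Measured compounds in a functional assay on the whole organism (strain NMRI) for inhibition, with Mus musculus as the target, in the formalin test, with a stated time of 30 min, at a dose of 30 umol/kg by the intraperitoneal route; on this read-out lower numbers stand for less inhibition and higher numbers for more inhibition at the one dose given (going by the name of the read-out):
compound 1 `S=c1[nH]nc(-c2ccccc2Sc2ccccc2)o1`, 13.1%
compound 2 `[O-][S+](c1ccccc1)c1ccccc1-c1n[nH]c(=S)o1`, 40.9%
compound 3 `O=S(=O)(c1ccccc1)c1ccccc1-c1n[nH]c(=S)o1`, 41.9%

Compound 1 gives the lowest number of the three in this assay; compound 2 and compound 3 both sit higher, each beyond the scatter of compound 1, while compound 2 and compound 3 lie within the scatter of each other.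

Compound 4 `S=c1[nH]nc(-c2ccccc2Sc2ccccc2Cl)o1` is not yet measured. It differs from compound 1 by chloro in place of hydrogen on an aromatic carbon. Among the measured compounds shown here, no pair of measured compounds shows the effect of this change, so the size of the step is unknown; a modest move, possibly within the scatter, is expected. The expected step of a number 6.9 percentage points higher from compound 1 to compound 4 (within the scatter) is small and upward. Compound 4 is estimated at 20%, with a range from 5% to 40%.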

Compound 4, a percentage reported as inhibition, in the whole organism at one dose (the size of the read-out at that dose, not a potency): 16.8%
Compound 4: the middle estimate sits 3.2 percentage points above what was measured; the measured number falls inside the stated range.
By their numbers in this assay, from the lowest: compounds 1 and 4 (each within the scatter of the next); then compounds 2 and 3 (each within the scatter of the next).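

In this assay, chloro in place of hydrogen on an aromatic carbon, ortho to a large group, gives a number 3.7 percentage points higher from compound 1 to compound 4 (within the scatter). This single chloro step therefore does not separate compound 4 from compound 1 at the one dose given. Nothing at hand explains this result.

Open, going by these compounds, is whether an amine, a methoxy group or a carboxylic acid at this place would separate from compound 1. Also open, on these data alone, is whether the same chloro step would read the same on compound 2 or compound 3.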